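Selenium carbamates: swapping the ester alkyl for phenyl

This account rests on a few compounds, and the source may have more. Where it says the series, first, only, none or still open, it means among the compounds named here.

Measured so far:
- compound 1, `CCCCCCOC(=O)Nc1ccc([Se][Se]c2ccc(NC(=O)OCCCCCC)cc2)cc1`: in a functional assay on PC-3 cells (Homo sapiens) for cytotoxicity, read by MTT assay, with a stated time of 72 h (a higher number here means a weaker inhibitor of growth, a lower number a stronger inhibitor of growth), compound 1 gives 600 nM
- compound 2, `CCCCCCOC(=O)Nc1ccc([Se]C#N)cc1`: compound 2 gives 17300 nM
- compound 3, `N#C[Se]c1ccc(NC(=O)OCc2ccc([N+](=O)[O-])cc2)cc1`: compound 3 gives 9000 nM

Compound 2 carries the highest number of the three measured compounds. Compound 3 stands nearest to it, and the gap between compound 2 and compound 3 lies within the usual scatter, so no order between the two can be read from the values. Compound 1 stands furthest, with a much lower number, and that gap lies beyond the scatter.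

Compound 4, `N#C[Se]c1ccc(NC(=O)Oc2ccccc2)cc1`, is not yet measured. Its structure differs from compound 2 in one place: phenyl in place of hexyl on an oxygen next to a carbonyl group. The rest of compound 2 is kept unchanged. Going by the values given here, no measured pair in the set differs by this change alone, so the size of the step has no direct precedent. Among the compounds with values here, the only guidance is that compound 2 and compound 3, which also differ only in the group on the oxygen next to the carbonyl group, give values within the scatter of each other.

On that basis the step from compound 2 to compound 4 is expected to be small, a 1.4-fold lower number from compound 2 to compound 4 (0.16 log units; within the scatter), with no direction that can be stated beyond the scatter. Compound 4 is estimated at 12000 nM in this assay, with a range from 4000 nM to 35000 nM.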

Compound 4, concentration for 50% growth inhibition: 9100 nM
Compound 4: the middle estimate sits 1.3-fold (0.12 log units) above what was measured; low and high end bracket the measured number.
By their numbers in this assay, from the lowest: compound 1; then compounds 3, 4 and 2 (each within the scatter of the next).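

In this assay, going by these compounds alone, the change on an oxygen next to a carbonyl group, phenyl in place of hexyl, gives a 1.9-fold lower number from compound 2 to compound 4 (0.28 log units; within the scatter), the first step read directly for a single change at this position. An open chain and an aromatic ring, each with 6 heavy atoms, therefore cannot be told apart here, and no order can be read between the two compounds. Nothing in the data at hand accounts for the size of this step.

On these data alone, whether an amine, a carboxylic acid or a chain longer than hexyl on this oxygen would give a step beyond the scatter remains open. As far as these compounds go, it is also open whether phenyl in place of hexyl would give a similarly small step in the setting of compound 1, which gives 600 nM in this assay.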